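A Nitrile Added to a Weak Kallikrein-7 Inhibitor

The compounds below may be only part of what the source reports. "The series", "measured", "known", "first", "only" and "open" are said of these compounds alone.

Measured compounds:
compound 1, `CC1=NC(c2cn(S(=O)(=O)c3ccc(Cl)cc3)c3ccccc23)CN1`, 5700 nM
compound 2, `CC1=NC(c2cn(S(=O)(=O)c3ccccc3)c3ccc(C)cc23)CN1`, 17000 nM

Both compounds were tested in an assay on isolated protein for inhibition of kallikrein-7 (Homo sapiens), read by fluorescence, with stated times of 10 min and 30 min; on this read-out lower numbers stand for stronger inhibition and higher numbers for weaker inhibition. Compound 1 gives 5700 nM, while compound 2 gives 17000 nM, the higher of the two numbers, and the gap between them lies beyond the usual scatter. The pair differs in two places at once, so no single change can be read from it.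

Compound 3, `CC1=NC(c2cn(S(=O)(=O)c3ccccc3C#N)c3ccc(C)cc23)CN1`, has not yet been measured. It differs from compound 2 by cyano in place of hydrogen on an aromatic carbon, so that the phenyl becomes a 2-cyanophenyl. Among the measured compounds shown here, no step between measured compounds shows what this change does, so the expectation rests on compound 2 alone. A small step toward lower numbers, possibly within the scatter, is expected, as a 1.7-fold lower number from compound 2 to compound 3 (0.23 log units; within the scatter). For compound 3 the estimated value is 10000 nM, with a range from 3000 nM to 30000 nM.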

Compound 3, half-maximal inhibitory concentration: 6700 nM
For compound 3 the middle estimate is 1.5-fold (0.17 log units) above the measured one; the range from low to high includes it.
By their numbers in this assay, from the lowest: compounds 1 and 3 (each within the scatter of the next); then compound 2.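

In this assay, among the compounds shown here, the change to 2-cyanophenyl gives a 2.5-fold lower number from compound 2 to compound 3 (0.40 log units; beyond the scatter) and so provides the first reading of a single change: a cyano group on this aromatic carbon, ortho to a large group, moves the number beyond the usual scatter. The step is modest, and compound 3 at 6700 nM remains a weak inhibitor, so this one addition does not turn the compound into a strong one. No measurement at hand explains why the number falls.

On these data alone, it remains open whether another group on the same carbon, such as an amine, a carboxylic acid or a methoxy group, would give a similar, larger or opposite step. Also unknown is whether a cyano group would have the same effect at another carbon of this ring, or on compound 1.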